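A Pyridine Ring for an Oxazole Ring: Expected Cytotoxicity

The source may hold more compounds than are shown below. What is called first, only, known or untested is meant among the compounds shown, and "the series" means these compounds.

The study looks at cytotoxicity in a toxicity assay on THP-1 cells (Homo sapiens) for inhibition (on this read-out higher numbers stand for lower toxicity in this test and lower numbers for higher toxicity in this test), across a small set of amides. Compound 1 `Cn1c(-c2ccc(Br)cc2)cnc1NC(=O)c1ccc(F)cc1` gives 46000 nM in this assay. For compound 3 `COc1ccc2nc(NC(=O)c3ccc(F)cc3)n(C)c2c1` this assay reports only a limit rather than a number, > 100000 nM. Compound 2 `COc1ccc(-c2cnc(NC(=O)c3ccno3)n2C)cc1` likewise returns a limit and not a measured number, > 100000 nM. Among the compounds with values here, compound 2 therefore stands at the limit of > 100000 nM in this assay, at which 2 of the 3 values shown sit, and with no step between measured compounds given, its distance from compound 1 cannot be expressed as a number. Compound 4 `COc1ccc(-c2cnc(NC(=O)c3ccncc3)n2C)cc1` has not yet been measured in this assay; it differs from compound 2 by pyridin-4-yl in place of 1,2-oxazol-5-yl on a carbonyl carbon. Within the data shown here, no measured step guides the size of this exchange, so the expectation is for no change beyond the scatter of this assay. The step from compound 2 to compound 4 is estimated as a number no higher from compound 2 to compound 4 (the limit leaves the size open), a step expected to remain within the usual scatter. Compound 4 is expected to show 100000 nM, within 30000 nM to 300000 nM, and most likely this assay will again report only a limit for it.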

Compound 4, half-maximal cytotoxic concentration: > 100000 nM
Compound 4: no number, only a limit; the forecaster's own chance of this, stated with the estimate: 65%; the middle value sits exactly at the limit.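

Compound 2 and compound 4 both end at a limit in this assay, so no step between them can be read: the limit of > 100000 nM in this assay, at which 3 of the 4 values shown sit.

The compounds shown leave open whether pyridin-4-yl in place of 1,2-oxazol-5-yl on a carbonyl carbon changes cytotoxicity at all, and by how much.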